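From tert-butyl to methoxy: working notes on compound 3

The source may hold more compounds than are shown below. What is called first, only, known or untested is meant among the compounds shown, and "the series" means these compounds.

In a functional assay on HT-29 cells (Homo sapiens) for cytotoxicity, read by MTT assay, with a stated time of 6 days (a lower number here means a stronger inhibitor, a higher number a weaker inhibitor), compound 1 (`Cc1ccc2c(c1)N(Cc1cn(Cc3ccccc3)nn1)C(=O)CO2`) is known only as a limit of the assay (> 100000 nM). In this assay, among the measured compounds shown here, compound 2 (`CC(C)(C)c1ccc(Cn2cc(CN3C(=O)COc4ccccc43)nn2)cc1`) gives 25100 nM as the only true number so far, so no measured step is available for calibration. Compound 3 (`COc1ccc(Cn2cc(CN3C(=O)COc4ccccc43)nn2)cc1`) carries methoxy in place of tert-butyl on an aromatic carbon, para to a large group (methoxy in place of tert-butyl on an aromatic carbon). A move toward weaker inhibition in this assay is expected, though its size is poorly constrained and a result reported only as a limit remains possible. This expectation rests on a single number, that of compound 2 (25100 nM), and is therefore tentative. The estimated change (a 2.0-fold higher number from compound 2 to compound 3 (0.30 log units; within the scatter)) is modest and upward. Compound 3 is estimated at 50000 nM with an expected range of 18000 nM to 100000 nM in this series.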

Compound 3, half-maximal inhibitory concentration: 18500 nM
For compound 3 the middle estimate is 2.7-fold (0.43 log units) above the measured one; measured number inside the range.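

In this assay, the change at this position now has a step that can be read: a 1.4-fold lower number from compound 2 to compound 3 (0.13 log units; within the scatter). On an aromatic carbon, para to a large group, methoxy and tert-butyl cannot be told apart in this assay, although the two groups differ in heavy atoms and methoxy adds a hydrogen-bond acceptor. Compound 1 remains a limit of the assay, and steps to it cannot be read: the limit of > 100000 nM in this assay, at which 1 of the 3 values shown sits.

The compounds shown leave open whether any group at this position moves the number beyond the scatter; an amine, a carboxylic acid or a longer chain in the same place would be informative. They also leave open whether methoxy in place of tert-butyl gives a similar step elsewhere on the ring or on another core.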